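A few compounds are considered here, and "the series" means these few. Any claim that something is new, unique, unknown or untested is made for them only; others in the source may bear on it.

Of the compounds shown here, three on a shared core have numbers so far in a functional assay on EBC-1 cells (Homo sapiens) for antiproliferative activity, with a stated time of 72 h (a higher number here means a weaker inhibitor, a lower number a stronger inhibitor), and they sit close together. There compound 1 `Cn1cc(-c2cc(F)c3ncc(Cc4ccc5ncccc5c4)n3c2)cn1` gives 0.27 nM and compound 2 `OCCn1cc(-c2cc(F)c3ncc(Cc4ccc5ncccc5c4)n3c2)cn1` gives 0.34 nM within the scatter of each other. Compound 3 `Fc1cc(-c2cnn(C3CCNCC3)c2)cn2c(Cc3ccc4ncccc4c3)cnc12` gives 1.46 nM as the highest number of the three. Compound 2 therefore stands with compound 1 at the low end and clearly under compound 3.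

Compound 4 `N#Cc1ccc(-c2cc(F)c3ncc(Cc4ccc5ncccc5c4)n3c2)cn1` carries 6-cyanopyridin-3-yl in place of 1-(2-hydroxyethyl)-1H-pyrazol-4-yl on an aromatic carbon of compound 2 (6-cyanopyridin-3-yl in place of 1-(2-hydroxyethyl)-1H-pyrazol-4-yl on an aromatic carbon). The measured steps alter only the group on an aromatic nitrogen. One of them (a 1.3-fold higher number from compound 1 to compound 2 (0.10 log units; within the scatter)) stays small, while two others (a 5.4-fold higher number from compound 1 to compound 3 (0.73 log units; beyond the scatter) and a 4.3-fold higher number from compound 2 to compound 3 (0.63 log units; beyond the scatter)) are modest. None replaces the whole group that leaves here, so they offer only a rough guide to how far a change at this end of the molecule can move the number. A modest rise of similar size is expected, though the lack of a direct precedent keeps the range wide. The estimated step is a 2.6-fold higher number from compound 2 to compound 4 (0.42 log units; beyond the scatter) in this assay and no larger shift is expected. For compound 4 the expected value is 0.9 nM (estimated range 0.25 nM to 3.5 nM).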

Compound 4, half-maximal inhibitory concentration: 189 nM
Compound 4: the middle estimate sits 210-fold (2.32 log units) below what was measured, outside the stated range (above it).
By their numbers in this assay, from the lowest: compounds 1 and 2 (each within the scatter of the next); then compound 3; then compound 4.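

In this assay, replacing the whole ring at this aromatic carbon, para to a fused ring, with 6-cyanopyridin-3-yl gives a 560-fold higher number from compound 2 to compound 4 (2.74 log units; beyond the scatter) and a 700-fold higher number from compound 1 to compound 4 (2.85 log units; beyond the scatter), both large. The changes on the aromatic nitrogen of the 1H-pyrazol-4-yl group went no further than a 5.4-fold higher number from compound 1 to compound 3 (0.73 log units; beyond the scatter), so compounds 1, 2 and 3 showed only that this end accepts different groups on that nitrogen, while compound 4 shows that the number is far more sensitive to exchange of the ring attached to the aromatic carbon; the leaving and entering groups both count 8 heavy atoms, so that count does not separate them. Nothing available here bears on which feature of this exchange accounts for the rise in the number.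

The compounds shown change the ring and add the nitrile in one step, so they leave open how much of the rise belongs to each. A plain pyridin-3-yl group, or a pyridin-3-yl group carrying an amine or a carboxylic acid where the nitrile stands, would help to separate the two, as would a 1H-pyrazol-4-yl group carrying a nitrile.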